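Cyanoguanidine series: benzoyl for 2-nitrophenyl at the amine

The source may hold more compounds than are shown below. What is called first, only, known or untested is meant among the compounds shown, and "the series" means these compounds.

Two compounds of the shared core have numbers in a functional assay on cardiac atrium for antagonist activity at histamine H2 receptor (Cavia porcellus) (a higher number here means a more potent compound, by a factor of ten per unit of this negative logarithm, a lower number a less potent compound), so far. Compound 1, `N#CN/C(=N\CCCNc1ccccc1[N+](=O)[O-])NCCCCOc1cccc(CN2CCCCC2)c1`, gives 7.85 in this assay. Compound 2, `N#CN/C(=N\CCNC(=O)c1ccc(N=[N+]=[N-])cc1)NCCCOc1cccc(CN2CCCCC2)c1`, which carries an amide-linked aryl group on a shorter chain, gives 7.9 in this assay. These two values lie within the scatter of one another, so no order between compound 1 and compound 2 can be read from them.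

Compound 3, `N#CN/C(=N\CCCNC(=O)c1ccccc1)NCCCCOc1cccc(CN2CCCCC2)c1`, is still to be measured in this assay. It differs from compound 1 in one place: benzoyl in place of 2-nitrophenyl on an amine nitrogen. Going by the values given here, no step between measured compounds covers this exchange. What can be said is that compound 2, with its aryl amide on the amine nitrogen, gives 7.9 in this assay, a number that sits with that of compound 1.

Compound 3 is therefore expected to stay close to compound 1, with an estimated step of a number 0.05 log units lower from compound 1 to compound 3 (within the scatter) in this assay, not beyond the scatter in either direction. The estimate for compound 3 in this assay is 7.8, with a range from 7.3 to 8.3.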

Compound 3, negative logarithm of the antagonist equilibrium constant: 6.6
Compound 3: middle estimate off by 1.20 log units, on the high side; the measured number lies below the stated range.
By their numbers in this assay, from the lowest: compound 3; then compounds 1 and 2 (each within the scatter of the next).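

In this assay, the group on this amine nitrogen proves not to be freely exchangeable: benzoyl in place of 2-nitrophenyl gives a number 1.25 log units lower from compound 1 to compound 3 (beyond the scatter), a large step for one change on otherwise identical chains. Going by these compounds alone, this is the first measured exchange at this position, and it shows that the series can respond strongly here, which the similar numbers of two compounds differing in more than one place could not reveal. No measurement at hand bears on the origin of the step, so the result stands as an observation only.

The exchange replaces 2-nitrophenyl with benzoyl in a single step, adding a carbonyl and removing a nitro group, so the compounds shown do not separate the contribution of either change. Plain phenyl or a nitrobenzoyl group on the same amine nitrogen would divide the step into its parts, while an azidobenzoyl group on the chains of compound 3 would show how far the amide-linked aryl group of compound 2 holds up on those chains.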